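The source may hold more compounds than are shown below. What is called first, only, known or untested is meant among the compounds shown, and "the series" means these compounds.

The series rests on a shared core that carries a phenyl-bearing enol chain, with three compounds in hand. Compound 1 `CCCOC1=C(CCC)C(=O)/C(=C(O)/C=C/c2ccccc2)C(=O)C1(CCC)CCC` gives, in a functional assay on 1A9 cells (Homo sapiens) for antiproliferative activity, read by sulforhodamine B assay, with a stated time of 3 days (on this read-out lower numbers stand for an effect already at smaller amounts and higher numbers for an effect only at larger amounts of compound), a value of 2 uM. Compound 2 `COC1=C(CC=C(C)C)C(=O)/C(=C(O)/C=C/c2ccccc2)C(=O)C1(CC=C(C)C)CC=C(C)C` was included in the set, but in this assay compound 2 stands only as "not determined" (no result reported), with no result reported for it. Compound 3 `CCCC1=C(OC)C(CCC)(CCC)C(=O)/C(=C(O)\C=C\c2ccc(I)cc2)C1=O`, which places an iodo group on the aromatic ring at the end of the chain, gives 1.8 uM in this assay. Among the two numbers available, compound 3 shows the lowest, but its gap to compound 1 is small enough to fall within the ordinary scatter of such measurements, so the two cannot be placed in any order of potency on this evidence.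

Compound 4 `CCCC1=C(OC)C(CCC)(CCC)C(=O)/C(=C(O)\C=C\c2ccc(Br)cc2)C1=O` follows from compound 3 by a single exchange at the halogen position: bromo in place of iodo on an aromatic carbon. Within the data shown here, no measured pair in this set isolates such a halogen swap, so the size of its effect is unknown here. On the strength of compound 3 at 1.8 uM alone, the step from compound 3 to compound 4 in this assay is expected to be a 1.1-fold higher number from compound 3 to compound 4 (0.05 log units; within the scatter), that is, no change beyond the scatter in either direction. Compound 4 is therefore estimated at 2 uM, within a range from 1 uM to 4 uM.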

Compound 4, concentration for half-maximal effect: 1.9 uM
Compound 4: the middle estimate sits 1.1-fold (0.02 log units) above what was measured; measured number inside the range.
By their numbers in this assay, from the lowest: compounds 3, 4 and 1 (each within the scatter of the next).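

In this assay, among these compounds, the exchange of iodo for bromo on an aromatic carbon gives the first step in this set that can be read at a single place (a 1.1-fold higher number from compound 3 to compound 4 (0.02 log units; within the scatter)). At this place on the six-membered aromatic ring, going from 4-iodophenyl to 4-bromophenyl therefore leaves the number within the scatter, so compound 3 and compound 4 cannot be told apart on this read-out, and the position accepts either halogen without a readable difference. No supporting measurement accompanies this result that could say anything about why the two halogens read alike.

As far as these compounds go, the two halogens cover only a narrow part of what this place could carry, so it remains open whether a methoxy group, an amine or a carboxylic acid there would also leave the number within the scatter. Compound 1 differs from compound 4 in more than one place and so cannot serve as a comparison without the halogen, and the effect of a longer chain in place of the propyl groups on the shared core also stays unresolved.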